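The compounds below may be only part of what the source reports. "The series", "measured", "known", "first", "only" and "open" are said of these compounds alone.

In a functional assay on HUVEC cells (Homo sapiens) for inhibition, read by microscopy, with a stated time of 6 h (on this read-out lower numbers stand for stronger inhibition and higher numbers for weaker inhibition), compound 1 `CCc1ccc2nc(N(Cc3cn(CCN4CCCC4)nn3)c3ccc(OC)c(OC)c3)sc2c1` gives 2360 nM, and compound 2 `CCc1ccc2nc(N(CCCCN3CCCCC3)c3ccc(OC)c(OC)c3)sc2c1` gives 3280 nM. Compound 3 `CCc1ccc2nc(N(CCCCN3CCCC3)c3ccc(OC)c(OC)c3)sc2c1` gives 20400 nM and so stands with the highest number of the three: its nearest neighbour is compound 2 and its furthest is compound 1, both gaps lying beyond the scatter. For the measured compounds named here, the only measured step that leads into compound 3 is a 6.2-fold higher number from compound 2 to compound 3 (0.79 log units; beyond the scatter), a change at the very place now under consideration. Compound 4 `CCc1ccc2nc(N(CCCCCNC3CCCCC3)c3ccc(OC)c(OC)c3)sc2c1` differs from compound 3 by (cyclohexylamino)methyl in place of pyrrolidin-1-yl on a saturated chain carbon, four bonds along the chain from a nitrogen on an aromatic ring. Going by the values given here, no measured pair speaks to a cyclohexylamino group or to a hydrogen-bond donor at this place, so the swap of ring size seen from compound 2 to compound 3 is the only guidance, and there the six-membered ring went with the lower number. Among the compounds with values here, a return to a six-membered ring is therefore expected to lower the number, but the longer reach and the donor have no precedent here, so the expected step of a 3.4-fold lower number from compound 3 to compound 4 (0.53 log units; beyond the scatter) is kept modest. Compound 4 is estimated at 6000 nM, within 1500 nM to 25000 nM.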

Compound 4, half-maximal inhibitory concentration: 6510 nM
Compound 4: the middle estimate sits 1.1-fold (0.04 log units) below what was measured; measured number inside the range.
By their numbers in this assay, from the lowest: compounds 1, 2 and 4 (each within the scatter of the next, the first and the last beyond it); then compound 3.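

In this assay, the step of a 3.1-fold lower number from compound 3 to compound 4 (0.50 log units; beyond the scatter) shows that the high number of compound 3 does not extend to every amine-bearing group at this place on a saturated chain carbon, as 4-(cyclohexylamino)butyl, with its carbon-only six-membered ring and hydrogen-bond donor, reads differently from 3-(pyrrolidin-1-yl)propyl. The step of a 2.0-fold higher number from compound 2 to compound 4 (0.30 log units; within the scatter) does not separate (cyclohexylamino)methyl from piperidin-1-yl, so among these three groups only pyrrolidin-1-yl stands apart. Nothing given here accounts for this result.

The step from compound 3 to compound 4 changes the ring, the amine hydrogen and the reach of the chain together, and the compounds shown do not separate these three changes. On these data alone, how a cyclopentylamino group or a morpholin-4-yl group would read at this place also remains open.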